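This account rests on a few compounds, and the source may have more. Where it says the series, first, only, none or still open, it means among the compounds named here.

Working notes on the series. The compounds share a core bearing an imidazole and a substituted aromatic nitrogen. Going by the values given here, compound 1 `O=S(=O)(Nc1cccc2c1CCCC2c1c[nH]cn1)C1CC1` is the weakest of the three measured so far: in an assay on isolated protein for binding affinity to Alpha-1D adrenergic receptor (Rattus norvegicus), read by radioligand binding (a lower number here means a stronger inhibitor, a higher number a weaker inhibitor), compound 1 gives 2690 nM, the highest of the three numbers. Compound 2 `CCS(=O)(=O)Nc1cccc2c1CCC2c1c[nH]cn1` gives 977 nM in this assay, and compound 3 `CCS(=O)(=O)Nc1cccc(Cc2c[nH]cn2)c1C` gives 1000 nM; both steps from compound 1 to these lie beyond the scatter, while compound 2 and compound 3 lie within the scatter of each other, so no order between those two is claimed. Among the compounds with values here, none of the measured pairs differs in a single place, so no counted step is available to lean on.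

Compound 4 `O=C(Nc1cccc2c1CCCC2c1c[nH]cn1)C(F)(F)F` has not yet been measured. It differs from compound 1 in one place: (trifluoromethyl)carbonyl in place of cyclopropylsulfonyl on a nitrogen on an aromatic ring. Within the data shown here, no measured pair shows this exchange, so the size of the step is unknown. The working expectation is that the step from compound 1 to compound 4 in this assay stays roughly within the scatter, a 1.1-fold higher number from compound 1 to compound 4 (0.05 log units; within the scatter), with wide uncertainty. Compound 4 is accordingly estimated at 3000 nM in this assay, with a range from 800 nM to 12000 nM.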

Compound 4, inhibition constant: 3310 nM
Beside the measured number, compound 4's estimate is 1.1-fold (0.04 log units) below it; the measured number falls inside the stated range.
By their numbers in this assay, from the lowest: compounds 2 and 3 (each within the scatter of the next); then compounds 1 and 4 (each within the scatter of the next).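

Going by these compounds alone, the exchange of cyclopropylsulfonyl for (trifluoromethyl)carbonyl on a nitrogen on an aromatic ring gives the only single-place step: in this assay it reads a 1.2-fold higher number from compound 1 to compound 4 (0.09 log units; within the scatter) and so does not separate the two groups at this position. They hold the same count of heavy atoms but differ in their atoms, in the three-membered ring and in hydrogen-bond acceptors, and none of these differences shows in this read-out. No measurement at hand offers an explanation for this result.

From the compounds shown here alone, it remains open how an amine, a carboxylic acid or a longer chain would read on the same nitrogen. Also open, going by these compounds, is whether the same exchange would read alike on the core of compound 2 or compound 3.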